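Methylsulfonyl for Methyl on a Diaryl Urea Series

The compounds below may be only part of what the source reports. "The series", "measured", "known", "first", "only" and "open" are said of these compounds alone.

Compound 1 `Cc1ccc(NC(=O)Nc2cccc(CNc3nccnc3Cl)c2)cc1`: 9820 nM
Compound 2 `Cc1ccc(NC(=O)Nc2cccc(CNc3nccnc3Cl)c2)cc1Cl`: 7390 nM
Compound 3 `Cc1ccccc1NC(=O)Nc1cccc(CNc2nccnc2Cl)c1`: 13600 nM

Of the compounds shown here, three sharing one core have been measured in a functional assay on T-24 cells (Homo sapiens) for antiproliferative activity, read by MTT assay, with a stated time of 48 h; a lower number here means a stronger inhibitor, a higher number a weaker inhibitor. Compound 1 stands second highest of the three numbers; its nearest neighbour is compound 2, reached by a 1.3-fold lower number from compound 1 to compound 2 (0.12 log units; within the scatter), and its furthest is compound 3, reached by a 1.4-fold higher number from compound 1 to compound 3 (0.14 log units; within the scatter). Between compound 2 and compound 3 the step is a 1.8-fold higher number from compound 2 to compound 3 (0.26 log units; within the scatter). Every step among the measured compounds falls within the scatter, so the three numbers cannot be ordered with confidence.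

Compound 4 `CS(=O)(=O)c1ccc(NC(=O)Nc2cccc(CNc3nccnc3Cl)c2)cc1` is not yet measured. It differs from compound 1 as follows: methylsulfonyl in place of methyl on an aromatic carbon. Among the compounds with values here, no measured step exchanges a methyl for a methylsulfonyl, so the steps from compound 1 to compounds 2 and 3 bear on it only as a sign that small changes on this aryl ring have moved the number little. The step into compound 4 is therefore expected to be small in this assay, with no clear direction beyond the scatter. For compound 4 the estimate is 12000 nM, between 4000 nM and 40000 nM, corresponding to an expected 1.2-fold higher number from compound 1 to compound 4 (0.09 log units; within the scatter).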

Compound 4, half-maximal inhibitory concentration: 29300 nM
Compound 4: middle estimate off by 2.4-fold (0.39 log units), on the low side; the range from low to high includes it.
By their numbers in this assay, from the lowest: compounds 2, 1 and 3 (each within the scatter of the next); then compound 4.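

In this assay, putting methylsulfonyl in place of methyl on the aromatic carbon para to a large group gives a 3.0-fold higher number from compound 1 to compound 4 (0.47 log units; beyond the scatter), a modest step towards weaker inhibition. Within the data shown here, this shows that the position is not indifferent to every change: the earlier steps on this aryl ring stayed within the scatter, whereas this one, with four heavy atoms and two hydrogen-bond acceptors entering for a single carbon, does not. No measurement at hand accounts for the step.

The compounds shown leave open whether the step is particular to methylsulfonyl or would recur with another group at this place, such as a nitrile, a carboxylic acid or an amine. They also leave open whether a smaller sulfur group, such as methylthio, would move the number at all.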